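Sulfonamide to ester swap on the shared core

A few compounds are considered here, and "the series" means these few. Any claim that something is new, unique, unknown or untested is made for them only; others in the source may bear on it.

For the measured compounds named here, compound 1 `CN1CCN(CCNCc2cn(-c3ccc([N+](=O)[O-])cc3)nc2-c2ccc(C(F)(F)F)cc2)CC1` and compound 2 `CN1CCN(CCNCc2cn(-c3ccc(F)cc3F)nc2-c2ccc(S(=O)(=O)N(C)C)cc2)CC1` share a core and differ in more than one place, so no single step between them is drawn. In an ADME assay on Huh-7 cells (Homo sapiens) for cytotoxicity (on this read-out higher numbers stand for lower toxicity in this test and lower numbers for higher toxicity in this test), compound 1 gives 3200 nM. In this assay compound 2 gives > 20000 nM, which is a limit of the assay rather than a number. Compound 2 thus stands at the limit of > 20000 nM in this assay, at which 1 of the 2 values shown sits, and that is all the two readings say about it.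

Compound 3 `COC(=O)c1ccc(-c2nn(-c3ccc(F)cc3F)cc2CNCCN2CCN(C)CC2)cc1` is reached from compound 2 by one change: methoxycarbonyl in place of dimethylsulfamoyl on an aromatic carbon. Going by the values given here, no measured step of this kind exists, so the expectation rests on the single limit reading for compound 2. The step in this assay is expected to be none beyond the scatter, the expected step being a number no higher from compound 2 to compound 3 (the limit leaves the size open). For compound 3 the estimate in this assay is 20000 nM, with a range from 8000 nM to 50000 nM, and a further limit reading is expected to be more likely than a number.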

Compound 3, half-maximal cytotoxic concentration: > 20000 nM
Compound 3: no number, only a limit (the forecaster's own chance of this, stated with the estimate: 55%); the middle value sits exactly at the limit.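

In this assay compound 3 gives > 20000 nM, which is a limit of the assay and not a number. For the compounds shown here, compound 2 also stands at a limit, so no step from compound 2 to compound 3 can be read. Still open, as far as these compounds go, is whether methoxycarbonyl in place of dimethylsulfamoyl changes this read-out at all, since neither compound has a numerical value.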